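The source may report more compounds than this note shows. Statements on the series, on what has been measured and on what is new or still open speak of the compounds shown alone.

Measured in an assay on isolated protein for inhibition of serine/threonine-protein kinase TNNI3K (Homo sapiens); a lower number here means a stronger inhibitor, a higher number a weaker inhibitor:
compound 1 `CNc1cc(Oc2ccc(NC(=O)Nc3cccc(C(F)(F)F)c3)cc2)ncn1`: 40 nM
compound 2 `CNc1cc(Oc2ccc(NC(=O)Nc3cccc(C(F)(F)F)c3)cc2Cl)ncn1`: 50 nM
compound 3 `CN(C)c1cc(Oc2ccc(NC(=O)Nc3cccc(C(F)(F)F)c3)cc2)ncn1`: 2500 nM

Compound 1 gives the lowest of the three numbers in this assay. Its step to compound 2, a 1.3-fold higher number from compound 1 to compound 2 (0.10 log units; within the scatter), is within the scatter, so these two are not told apart by this assay. Going by the values given here, its step to compound 3, a 63-fold higher number from compound 1 to compound 3 (1.80 log units; beyond the scatter), is large and is the only change among the measured compounds that moves the number beyond the scatter.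

Compound 4 `CNc1cc(Oc2ccc(NC(=O)Nc3cccc(C(C)F)c3)cc2)ncn1` has not yet been measured in this assay. It differs from compound 1 in one place: 1-fluoroethyl in place of trifluoromethyl on an aromatic carbon. Neither measured step bears directly on this change. The step of a 1.3-fold higher number from compound 1 to compound 2 (0.10 log units; within the scatter) puts a chloro on the other aromatic ring, and the step of a 63-fold higher number from compound 1 to compound 3 (1.80 log units; beyond the scatter) puts a methyl on the nitrogen of the shared core, while the trifluoromethyl is kept in compounds 1, 2 and 3. The expectation for compound 4 therefore rests only on the rest of the molecule being unchanged and on the size of the group being altered. A modest step towards a higher number is expected, a 3.0-fold higher number from compound 1 to compound 4 (0.48 log units; beyond the scatter), with wide uncertainty. Compound 4 is estimated at 120 nM, within a range from 30 nM to 500 nM.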

Compound 4, half-maximal inhibitory concentration: 79 nM
Compound 4: middle estimate off by 1.5-fold (0.18 log units), on the high side; the measured number falls inside the stated range.
By their numbers in this assay, from the lowest: compounds 1, 2 and 4 (each within the scatter of the next); then compound 3.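

In this assay, the position on the aromatic ring meta to a large group, which carried trifluoromethyl in compounds 1, 2 and 3, now has a first replacement: exchanging trifluoromethyl for 1-fluoroethyl gives a 2.0-fold higher number from compound 1 to compound 4 (0.30 log units; within the scatter). Going by these compounds alone, this assay therefore does not tell the two groups apart at this position, so trifluoromethyl is not the only group here compatible with a number in the range of compound 1, in contrast to the large step at the nitrogen on the shared core, a 63-fold higher number from compound 1 to compound 3 (1.80 log units; beyond the scatter). No measurement at hand accounts for how the two groups compare at this position, so this remains an observation from a single pair of compounds.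

The compounds shown leave open how far this position accepts other groups, such as an unfluorinated ethyl, a nitrile, an amine, a carboxylic acid or a longer alkyl chain. They also leave open whether 1-fluoroethyl behaves the same way when combined with the chloro of compound 2, and whether the two mirror-image forms of the 1-fluoroethyl group give the same number.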